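This account rests on a few compounds, and the source may have more. Where it says the series, first, only, none or still open, it means among the compounds named here.

Working notes on the series.

Compound 1 `O=C(c1ccccc1)c1cccc(NS(=O)(=O)c2ccc(Cl)cc2Cl)c1` carries a 2,4-dichlorophenylsulfonyl group on a sulfonamide nitrogen; in an assay on CHO cells for binding affinity to integrin alpha-1 (Homo sapiens), read by WST assay, with a stated time of 2 h, tested at 50 uM (on this read-out lower numbers stand for less inhibition and higher numbers for more inhibition at the one concentration tested (going by the name of the read-out)), compound 1 gives 69%. Compound 2 `CN(c1cccc(C(=O)c2ccccc2)c1)S(=O)(=O)c1ccc(Cl)cc1Cl` bears a methyl on that nitrogen, and compound 2 gives 8%; the change from compound 1 to compound 2 is a number 61 percentage points lower from compound 1 to compound 2 (beyond the scatter), methyl in place of hydrogen on a sulfonamide nitrogen. Compound 3 `O=C(c1ccccc1)c1ccc(NS(=O)(=O)c2ccccc2)cc1` has an unsubstituted phenylsulfonyl group and the benzoyl group on a different position of the shared core; compound 3 gives 0%, the lowest of the three numbers, within the scatter of compound 2 and well below compound 1.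

Compound 4 `O=C(c1ccccc1)c1ccc(NS(=O)(=O)c2ccc(I)cc2)cc1` is the next step from compound 3: iodo in place of hydrogen on an aromatic carbon. For the measured compounds named here, no measured step tracks a halogen on the sulfonyl ring alone, since compound 1 differs from compound 3 in two places at once, and the only single step, from compound 1 to compound 2, concerns the nitrogen. Going by the values given here, the direction is therefore open; a modest rise is expected, a number 15 percentage points higher from compound 3 to compound 4 (beyond the scatter), on the ground that compound 1, the only halogenated member, gives 69%. For compound 4 the expected value is 15%, in the range 0% to 45%.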

Compound 4, a percentage reported as inhibition, at one concentration (the size of the read-out at that concentration, not a potency): 85%
Compound 4: the middle estimate sits 70 percentage points below what was measured; the measured number lies above the stated range.
By their numbers in this assay, from the lowest: compounds 3 and 2 (each within the scatter of the next); then compound 1; then compound 4.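

In this assay the iodo in place of hydrogen on an aromatic carbon, para to a large group, gives a number 85 percentage points higher from compound 3 to compound 4 (beyond the scatter) and is the only single change shown that raises the number. The step isolates the sulfonyl ring: phenyl to 4-iodophenyl alone carries a large rise, with the sulfonamide nitrogen and the rest of the shared core unchanged, whereas the two differences between compound 1 and compound 3 could not be separated. Nothing measured in the series bears on the reason for this rise.

The compounds shown do not tell whether a chloro, a bromo, an amine or a carboxylic acid at this place would give a similar number. Also open, from the compounds shown here alone, is whether the 4-iodophenyl group keeps its effect with the benzoyl group placed as in compound 1, or with a methyl on the sulfonamide nitrogen.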